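Removing a Methoxy Group: From Compound 2 to Compound 3

The source may hold more compounds than are shown below. What is called first, only, known or untested is meant among the compounds shown, and "the series" means these compounds.

Of the compounds shown here, two have been measured in a functional assay on the whole organism (strain albino) for inhibition, with Rattus norvegicus as the target, read by paw edema, with stated times of 30 min and 2 h, at a dose of 100 mg/kg by the oral route; on this read-out lower numbers stand for less inhibition and higher numbers for more inhibition at the one dose given (going by the name of the read-out). Compound 1 `COc1ccc(C2=NNC(c3ccco3)C2)cc1OC` gives 53% in this assay, and compound 2 `COc1ccc(C2=NNC(c3c(Cl)cccc3Cl)C2)cc1OC` gives 49%, the smaller of the two numbers, though the distance to compound 1 lies within the scatter. Compound 3 `COc1ccc(C2=NNC(c3c(Cl)cccc3Cl)C2)cc1` differs from compound 2 by hydrogen in place of methoxy on an aromatic carbon. Going by the values given here, no step between measured compounds is at hand to size this change, so a modest decrease, not clearly beyond the scatter, is expected. Compound 3 is therefore expected to show an estimated step of a number 6 percentage points lower from compound 2 to compound 3 (within the scatter). Compound 3 is expected to give 43%, in a range from 28% to 57%.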

Compound 3, a percentage reported as inhibition, in the whole organism at one dose (the size of the read-out at that dose, not a potency): 58%
Beside the measured number, compound 3's estimate is 15 percentage points below it; measured number above the stated range.
By their numbers in this assay, from the lowest: compounds 2, 1 and 3 (each within the scatter of the next).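

In this assay there is a number 9 percentage points higher from compound 2 to compound 3 (within the scatter) when hydrogen takes the place of methoxy on an aromatic carbon, ortho to a methoxy group. This first step measured at this position shows that the methoxy group can be lost without a change beyond the scatter, so it is not shown to be needed for this read-out at the one dose given. No measurement at hand offers an explanation for this result. On these data alone, whether the methoxy group that remains in compound 3 can also be lost stays open, as does whether an amine or a hydroxyl group at this position would give a step beyond the scatter.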